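Extending a Hydroxy Chain on a Sulfonamide Core

The compounds below may be only part of what the source reports. "The series", "measured", "known", "first", "only" and "open" are said of these compounds alone.

Two pairs of compounds here share one small change. Compound 1 `NS(=O)(=O)c1ccc(SCCO)c(F)c1` carries a hydroxy group at the end of a short chain, and compound 2 `NS(=O)(=O)c1ccc(SCCCO)c(F)c1` differs from it by hydroxymethyl in place of hydroxy on a saturated chain carbon, two bonds along the chain from a sulfur. In a physicochemical assay for acid dissociation, compound 1 gives 9.76, and compound 2 gives 9.64; the step between them is a number 0.12 log units lower from compound 1 to compound 2 (within the scatter).

Compound 3 `Nc1cc(S(N)(=O)=O)ccc1S(=O)(=O)CCO` rests on another core; the difference between the two cores is not broken down here. In this assay compound 3 gives 9.5, which sits within the scatter of both compound 1 and compound 2. Compound 4 `Nc1cc(S(N)(=O)=O)ccc1S(=O)(=O)CCCO` has not yet been measured and differs from compound 3 by hydroxymethyl in place of hydroxy on a saturated chain carbon, two bonds along the chain from a sulfonyl sulfur. The surroundings of the place are not identical: in the first pair the chain carbon is two bonds along the chain from a sulfur, in the second it is two bonds along the chain from a sulfonyl sulfur. It is therefore the same kind of change, not the same change.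

Because a number 0.12 log units lower from compound 1 to compound 2 (within the scatter) stayed within the scatter, the expected step for compound 4 is likewise small, a number 0.10 log units lower from compound 3 to compound 4 (within the scatter). Compound 4 is estimated at 9.4 in this assay, with an expected range from 9.1 to 9.7.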

Compound 4, acid dissociation constant: 9.15
Compound 4: the middle estimate sits 0.25 log units above what was measured, within the range that was stated.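

On the core of compound 3, the change from hydroxy to hydroxymethyl gives, in this assay, a number 0.35 log units lower from compound 3 to compound 4 (beyond the scatter) on the read-out, while on the core of compound 1 the same kind of change gives a number 0.12 log units lower from compound 1 to compound 2 (within the scatter) and so cannot be told apart from repeat-measurement noise. This shows that the size of the step did not simply carry over from one core to the other: a step that stayed within the scatter on the first core lies beyond it on the second, though the second step is still only modest. For the compounds shown here, it does not show a general rule, as there are only two pairs and the chain sits in different surroundings in each, two bonds along from a sulfur in one and from a sulfonyl sulfur in the other, and nothing available here explains why the two steps differ.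

The compounds shown leave open which of the differences between the two cores goes with the larger step, as no pair here isolates any one of them. Also open, on these data alone, is how the read-out would respond on either core to a longer chain, or to an amine or a carboxylic acid at the end of the chain in place of the hydroxy group.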